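Trifluoromethyl removal on the aryl-substituted amide series

The source may report more compounds than this note shows. Statements on the series, on what has been measured and on what is new or still open speak of the compounds shown alone.

Measured so far:
Compound 1 `CNC(=O)c1cc(Oc2ccc(NC(=O)c3nccc(-c4ccc(OC)cc4)n3)cc2)ccn1` — 35200 nM
Compound 2 `CNC(=O)c1cc(Oc2ccc(NC(=O)c3cc(-c4ccc(C(F)(F)F)cc4)ncn3)cc2F)ccn1` — > 100000 nM

Two compounds carry numbers in a functional assay on MCF7 cells (Homo sapiens) for cytotoxicity, read by MTT assay, with a stated time of 72 h; on this read-out higher numbers stand for weaker inhibition and lower numbers for stronger inhibition. Compound 1 gives 35200 nM in this assay. Compound 2 does not reach a number: in this assay compound 2 stops at the limit of the assay, > 100000 nM. Among the compounds with values here, the two differ in several places at once, so no single step between them can be read. Within the data shown here, the only evidence on the measured set is the limit of > 100000 nM in this assay, at which 1 of the 2 values shown sits.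

Compound 3 `CNC(=O)c1cc(Oc2ccc(NC(=O)c3cc(-c4ccccc4)ncn3)cc2F)ccn1` is the next entry. It differs from compound 2 in one place, hydrogen in place of trifluoromethyl on an aromatic carbon — the same change cut one bond further out reads 4-(trifluoromethyl)phenyl to phenyl. With compound 2 sitting at the limit, the step of an at least 1.2-fold lower number from compound 2 to compound 3 (0.09 log units; that floor lies within the scatter) is expected to stay small, with no change beyond the scatter. On that basis compound 3 is estimated at 80000 nM, in a range from 30000 nM to 150000 nM.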

Compound 3, half-maximal inhibitory concentration: 32400 nM
Beside the measured number, compound 3's estimate is 2.5-fold (0.39 log units) above it, within the range that was stated.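

In this assay, within the data shown here, hydrogen in place of trifluoromethyl on an aromatic carbon, para to a large group, gives an at least 3.0-fold lower number from compound 2 to compound 3 (0.48 log units; beyond the scatter) and provides the first single-place comparison. The value for compound 2, > 100000 nM, is a limit of the assay and not a number. The step is therefore only a floor, and its full size stays unknown, because one of its ends rests on that limit: the limit of > 100000 nM in this assay, at which 1 of the 3 values shown sits.

Only hydrogen and trifluoromethyl can be compared at this carbon, so the compounds shown do not tell how a chlorine atom, an amine or a carboxylic acid there would read. Among these compounds, compound 1 differs from compound 2 and compound 3 in several places, so no step to it can be read.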